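Taking the chloro group off compound 3

The source may report more compounds than this note shows. Statements on the series, on what has been measured and on what is new or still open speak of the compounds shown alone.

Measured in an ADME assay on MRC5 cells (Homo sapiens) for cytotoxicity, read by MTT assay, with a stated time of 24 h (on this read-out lower numbers stand for higher toxicity in this test and higher numbers for lower toxicity in this test), so far:
compound 1 `CC1(C)[C@H]2CC[C@]1(C)N(Cc1cn(-c3ccc(C#N)cc3)nn1)C(=O)C2` gives 10800 nM
compound 2 `CC1(C)[C@H]2CC[C@]1(C)N(Cc1cn(-c3ccccc3C#N)nn1)C(=O)C2` gives 23300 nM
compound 3 `CC1(C)[C@H]2CC[C@]1(C)N(Cc1cn(-c3cccc(Cl)c3)nn1)C(=O)C2` gives 8840 nM

These three compounds share one core and differ only in the substituted phenyl group on an aromatic nitrogen. Compound 3 stands level with compound 1 on these numbers, since the data show a 1.2-fold lower number from compound 1 to compound 3 (0.09 log units; within the scatter) and no real difference. It stands clearly apart from compound 2, with a 2.6-fold lower number from compound 2 to compound 3 (0.42 log units; beyond the scatter) as the measured gap.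

The next compound is compound 4 `CC1(C)[C@H]2CC[C@]1(C)N(Cc1cn(-c3ccccc3)nn1)C(=O)C2` and it differs from compound 3 by one small change hydrogen in place of chloro on an aromatic carbon on an aromatic carbon, meta to a large group, where hydrogen comes in place of chloro. The result is a plain phenyl group. For the measured compounds named here, no measured step removes a chloro group directly, so the evidence is only indirect. Besides the two steps above, there is a 2.2-fold higher number from compound 1 to compound 2 (0.33 log units; beyond the scatter) to consider, and all three swap one whole substituted phenyl group for another. None of them is more than modest, so a small rise in this assay is expected, quite possibly none beyond the scatter. The estimate means a 1.4-fold higher number from compound 3 to compound 4 (0.15 log units; within the scatter) as the expected step. For compound 4 the estimated value is 12500 nM (expected range 6500 nM to 24000 nM).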

Compound 4, half-maximal cytotoxic concentration: 9730 nM
Estimate against measurement, compound 4: 1.3-fold (0.11 log units) above, within the range that was stated.
By their numbers in this assay, from the lowest: compounds 3, 4 and 1 (each within the scatter of the next); then compound 2.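

In this assay, hydrogen in place of chloro on an aromatic carbon, meta to a large group, gives a 1.1-fold higher number from compound 3 to compound 4 (0.04 log units; within the scatter), so this direct comparison shows no readable effect of the chloro group at this place. The plain phenyl group also offers a bare reference for the two cyano compounds: replacing the cyano group with hydrogen gives a 1.1-fold lower number from compound 1 to compound 4 (0.05 log units; within the scatter), which cannot be told from no change, but also a 2.4-fold lower number from compound 2 to compound 4 (0.38 log units; beyond the scatter), a modest step that leaves the compound with the 2-cyanophenyl group as the only one of the four standing apart. Nothing measured here explains why the numbers fall this way.

On these data alone, it remains open whether a different group at the place that held the chloro, such as an amine, a carboxylic acid or a longer carbon chain, would shift the number beyond the scatter. As far as these compounds go, it also remains open whether the higher number of compound 2 belongs to the cyano group itself or would also appear with a chloro group placed where that cyano group sits.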